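The compounds below may be only part of what the source reports. "The series", "measured", "known", "first", "only" and "open" are said of these compounds alone.

Working notes on the series. In a physicochemical assay for lipophilicity, read by HPLC, measured as octanol-water partition, at pH 7.2 (a higher number here means a more lipophilic compound, a lower number a more polar compound), compound 1 (`CC(=O)c1ccc(NC(=O)Nc2ccc(F)c(C(F)(F)F)c2)cc1`) gives 3.6 while compound 2 (`O=C(Nc1ccc(C(=O)O)cc1)Nc1ccc(F)c(C(F)(F)F)c1`) gives 1.5 and compound 3 (`O=C(Nc1ccnc(C(F)(F)F)c1)Nc1ccc(F)c(C(F)(F)F)c1`) gives 3.8 on the same scale. Compound 2 holds the lowest of these three numbers, and its gaps to compound 1 and to compound 3 both lie beyond the scatter.

Compound 4 (`NC(=O)c1ccc(NC(=O)Nc2ccc(F)c(C(F)(F)F)c2)cc1`) has not been measured yet. The change from compound 2 to compound 4 is amino in place of hydroxy on a carbonyl carbon, which reads carboxy to carbamoyl when cut one bond further out.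

Within the data shown here, one measured step bears on this place. It is a number 2.10 log units lower from compound 1 to compound 2 (beyond the scatter) and it is large, with hydroxy in place of methyl on a carbonyl carbon. Among the measured compounds shown here, no single-place step ties compound 3 to this change, and no measured compound carries amino on this carbonyl carbon, so the expectation rests on that one step alone. Compound 4 is expected to regain much of that drop, yet to remain under compound 1 at 3.6 in this assay on this limited evidence. The expected step is a number 1.40 log units higher from compound 2 to compound 4 (beyond the scatter) and it points upward, beyond the scatter. Compound 4 is estimated at 2.9 with 2.4 as the expected lower end and 3.4 as the upper end.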

Compound 4, distribution coefficient: 2.7
Beside the measured number, compound 4's estimate is 0.20 log units above it, within the range that was stated.
By their numbers in this assay, from the lowest: compound 2; then compound 4; then compounds 1 and 3 (each within the scatter of the next).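

In this assay this carbonyl carbon now carries three groups on one shared core, and the change from hydroxy to amino gives a number 1.20 log units higher from compound 2 to compound 4 (beyond the scatter) as a step of its own, so the low reading of compound 2 is not shared by every group that differs from methyl here. Amino does not bring the series back level with methyl, however, since the remaining gap is a number 0.90 log units lower from compound 1 to compound 4 (beyond the scatter) and places compound 4 at a distinct level that the single earlier step could not reveal. No measurement shown gives a reason for this order of hydroxy, amino and methyl.

As far as these compounds go, what a methylamino or a dimethylamino group would read on this carbonyl carbon remains open, as does the reading of a methoxy group, which would show how a carboxylic ester compares with the carboxy and carbamoyl forms. The change from carboxy to carbamoyl is also seen in one pair only, so whether its size holds on a different core, such as one bearing the trifluoromethyl group of compound 3, cannot be told.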